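Fluoro in place of hydrogen: compound 1 to compound 3

The source may report more compounds than this note shows. Statements on the series, on what has been measured and on what is new or still open speak of the compounds shown alone.

Measured in a functional assay on the whole organism (strain albino) with Mus musculus as the target, in the maximal electroshock model, with a stated time of 0.5 h; on this read-out lower numbers stand for an effect already at smaller amounts and higher numbers for an effect only at larger amounts of compound:
Compound 1 `O=C1c2ccccc2C(=O)N1c1ccccc1`: 66.2 mg/kg
Compound 2 `O=C1c2ccccc2C(=O)N1c1cccc(F)c1`: 39.7 mg/kg

With only these two numbers available, compound 1 cannot be separated from compound 2, as the step between them is a 1.7-fold lower number from compound 1 to compound 2 (0.22 log units; within the scatter). Compound 3 `O=C1c2ccccc2C(=O)N1c1ccc(F)cc1` has not yet been measured. It differs from compound 1 by fluoro in place of hydrogen on an aromatic carbon, para to a large group: fluoro in place of hydrogen on an aromatic carbon. Among the measured compounds shown here, one measured step bears on this change, the same exchange at a different carbon of that ring, and it amounts to a 1.7-fold lower number from compound 1 to compound 2 (0.22 log units; within the scatter). A single step is thin evidence, and it says nothing direct about the new place. In this assay, no change beyond the scatter is therefore expected, the estimate being a 1.3-fold lower number from compound 1 to compound 3 (0.12 log units; within the scatter). For compound 3 the expected value is 50 mg/kg, with an estimated range from 25 mg/kg to 100 mg/kg.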

Compound 3, dose for half-maximal effect: > 300 mg/kg
Compound 3: only a limit was reported; the forecaster's own chance of this, stated with the estimate: 10%; middle value at least 6.0-fold (0.77 log units) away from the limit.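

Para to a large group, fluoro in place of hydrogen on an aromatic carbon moves the read-out beyond the scatter, with an at least 4.5-fold higher number from compound 1 to compound 3 (0.65 log units; beyond the scatter), whereas the same exchange at a different carbon of that ring gave only a 1.7-fold lower number from compound 1 to compound 2 (0.22 log units; within the scatter). In this assay, from the compounds shown here alone, compound 3 gives > 300 mg/kg, which is a limit of the assay and not a number, so the full size of the step stays unknown. This is the only value of its kind among the compounds shown: the limit of > 300 mg/kg in this assay, at which 1 of the 3 values shown sits.

The compounds shown leave open whether this shift belongs to fluoro alone or would follow any group on this carbon. An amine or a methoxy group at the same place would bear on that question, and neither stands among them.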